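Replacing the Piperazine Arm of Compound 1

A few compounds are considered here, and "the series" means these few. Any claim that something is new, unique, unknown or untested is made for them only; others in the source may bear on it.

Going by the values given here, compound 1 `CCCCCCCCCCc1ccc(-c2noc(CN3CCNCC3)n2)cc1` has, in an assay on HeLa cells for inhibition of sphingosine-1-phosphate transporter SPNS2 (Mus musculus), read by LC-MS, tested at 2 uM (on this read-out lower numbers stand for less inhibition and higher numbers for more inhibition at the one concentration tested (going by the name of the read-out)), the lowest of the two numbers so far: compound 1 gives 19%. Among the compounds with values here, its only measured neighbour is compound 2 `CCCCCCCCCCc1ccc(-c2noc([C@H](N)CCCCN)n2)cc1`, which in this assay gives 50%, so that the change reads a number 31 percentage points higher from compound 1 to compound 2 (beyond the scatter). The unmeasured compound 3 `CCCCCCCCCCc1ccc(-c2noc(CCCN3CCCC3)n2)cc1` is built from compound 1 by 2-(pyrrolidin-1-yl)ethyl in place of piperazin-1-yl on a saturated chain carbon bound to an aromatic carbon. Within the data shown here, no measured step shows this particular change; the one step known, from compound 1 to compound 2, concerns a different group, and it was large, yet it offers only a loose guide here. For compound 3 the author therefore expects no strong shift in either direction, with a step of about a number 6 percentage points higher from compound 1 to compound 3 (within the scatter) carrying wide uncertainty. Compound 3 is estimated at 25% in this assay, within a range from 5% to 50%.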

Compound 3, a percentage reported as inhibition, at one concentration (the size of the read-out at that concentration, not a potency): 3%
Estimate against measurement, compound 3: 22 percentage points above, outside the stated range (below it).
By their numbers in this assay, from the lowest: compound 3; then compound 1; then compound 2.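

In this assay, the arm on this saturated chain carbon can lower the reading as well as raise it: 3-(pyrrolidin-1-yl)propyl in place of (piperazin-1-yl)methyl gives a number 16 percentage points lower from compound 1 to compound 3 (beyond the scatter) and so does not preserve the level of compound 1. Measured against the 1,5-diaminopentyl arm, the same group gives a number 47 percentage points lower from compound 2 to compound 3 (beyond the scatter) and places the three arms in a clear order, with compound 2 on top and compound 3 at the bottom. No measurement at hand explains this fall.

Going by these compounds, this step changes both the chain and the ring, so it remains open which of them goes with the lower reading; a (pyrrolidin-1-yl)methyl arm or a 3-(piperazin-1-yl)propyl arm would separate the two. Also open, on these data alone, is how a guanidine at the end of the chain would read.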